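This account rests on a few compounds, and the source may have more. Where it says the series, first, only, none or still open, it means among the compounds named here.

Compound 3 `CN1C[C@H](C(=O)Nc2ccc(C(F)(F)F)cc2)[C@@H](c2ccc(/C=C/C(=O)Nc3ccccc3N)cc2)C1` gives 23 mL/min/kg in an in vitro ADME assay on microsomes from liver (Mus musculus) for pharmacokinetics, read by LC-MS, with a stated time of 10 min, tested at 1 uM (a higher number here means faster removal of the compound, a lower number slower removal), the lowest of the three numbers in hand. Compound 2 `CN1C[C@H](C(=O)Nc2ccc(C#N)cc2)[C@@H](c2ccc(/C=C/C(=O)Nc3ccccc3N)cc2)C1` gives 35 mL/min/kg and compound 1 `CN1C[C@H](C(=O)Nc2ccccc2)[C@@H](c2ccc(/C=C/C(=O)Nc3ccccc3N)cc2)C1` gives 67 mL/min/kg; the gap a 1.5-fold lower number from compound 2 to compound 3 (0.18 log units; within the scatter) lies within the scatter, whereas a 2.9-fold lower number from compound 1 to compound 3 (0.46 log units; beyond the scatter) lies beyond it. Compound 4 `CN1C[C@H](C(=O)Nc2ccc(F)c(Cl)c2)[C@@H](c2ccc(/C=C/C(=O)Nc3ccccc3N)cc2)C1` differs from compound 3 by 3-chloro-4-fluorophenyl in place of 4-(trifluoromethyl)phenyl on an amide-type nitrogen. Among the compounds with values here, the measured steps that touch the leaving group are a 2.9-fold lower number from compound 1 to compound 3 (0.46 log units; beyond the scatter) and a 1.5-fold lower number from compound 2 to compound 3 (0.18 log units; within the scatter); no measured step covers the entering 3-chloro-4-fluorophenyl. Because compound 2 gives 35 mL/min/kg and compound 3 gives 23 mL/min/kg, a change within the scatter is expected for compound 4, a 1.3-fold higher number from compound 3 to compound 4 (0.12 log units; within the scatter). Compound 4 is estimated at 30 mL/min/kg, within 15 mL/min/kg to 60 mL/min/kg.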

Compound 4, clearance: 34 mL/min/kg
Estimate against measurement, compound 4: 1.1-fold (0.05 log units) below; the range from low to high includes it.
By their numbers in this assay, from the lowest: compounds 3, 4, 2 and 1 (each within the scatter of the next, the first and the last beyond it).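

With 3-chloro-4-fluorophenyl on the amide-type nitrogen, this assay gives a 1.5-fold higher number from compound 3 to compound 4 (0.17 log units; within the scatter) and a 1.0-fold lower number from compound 2 to compound 4 (0.01 log units; within the scatter), so this group cannot be told apart from 4-(trifluoromethyl)phenyl or 4-cyanophenyl here. Within the data shown here, from the phenyl of compound 1, the step is a 2.0-fold lower number from compound 1 to compound 4 (0.29 log units; within the scatter), which leaves a 2.9-fold lower number from compound 1 to compound 3 (0.46 log units; beyond the scatter) as the only step from compound 1 beyond the scatter. Nothing available bears on the reason for these steps.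

Still open, as far as these compounds go, is how an amine or a carboxylic acid on the phenyl ring would read in this position. From the compounds shown here alone, a longer chain in place of the ring on the amide-type nitrogen is equally open.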